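Oxolan-2-yl for oxan-2-yl in a series held at the limit

This account rests on a few compounds, and the source may have more. Where it says the series, first, only, none or still open, it means among the compounds named here.

Compound 1 (`Oc1ccccc1CNc1ncnc2c1ncn2C1CCCCO1`) is the starting point. In an ADME assay on K562 cells (Homo sapiens) for cytotoxicity, with a stated time of 72 h (a higher number here means a weaker inhibitor, a lower number a stronger inhibitor), compound 1 gives > 100000 nM as a limit and not a number. Compound 2 (`Oc1ccc(CNc2ncnc3c2ncn3C2CCCCO2)cc1`) gives > 100000 nM as a limit too. Compound 3 (`COc1cccc(CNc2ncnc3c2ncn3C2CCCCO2)c1O`) gives > 100000 nM as a limit too. The 4-hydroxyphenyl exchange makes a step that the two limits leave unreadable from compound 1 to compound 2 and the added methoxy makes a step that the two limits leave unreadable from compound 1 to compound 3 and neither touches the group changed here.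

Compound 4 (`Oc1ccccc1CNc1ncnc2c1ncn2C1CCCO1`) differs from compound 1 by oxolan-2-yl in place of oxan-2-yl on an aromatic nitrogen with oxolan-2-yl in place of oxan-2-yl on an aromatic nitrogen. Among the compounds with values here, no measured step covers this exchange. The expectation rests on the limit of compound 1 at > 100000 nM and on the limit of > 100000 nM in this assay, at which 3 of the 3 values shown sit, alone. In this assay the expected outcome is a number no higher from compound 1 to compound 4 (the limit leaves the size open) with no step beyond the scatter in either direction. Compound 4 is estimated at 100000 nM with a range from 40000 nM to 200000 nM and will probably read as a limit again.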

Compound 4, half-maximal inhibitory concentration: > 100000 nM
Compound 4 gave a limit, no number; the forecaster's own chance of this, stated with the estimate: 80%; the middle value sits exactly at the limit.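

Within the data shown here, compound 1 and compound 4 both stand as limits in this assay, so no step between them can be read. The compounds shown leave open how any of them ranks, because all stand at one limit: the limit of > 100000 nM in this assay, at which 4 of the 4 values shown sit.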